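A few compounds are considered here, and "the series" means these few. Any claim that something is new, unique, unknown or untested is made for them only; others in the source may bear on it.

Measured so far in an assay on isolated protein for inhibition of vascular endothelial growth factor receptor 1 (Homo sapiens), read by ELISA, with a stated time of 20 min, tested at 1 uM; on this read-out higher numbers stand for more inhibition at the one concentration tested (going by the name of the read-out) and lower numbers for less inhibition:
- compound 1 `COc1cc2ncnc(Nc3cccc(C(=O)O)c3)c2cc1OC`: 32%
- compound 2 `COc1cc2ncnc(Nc3ccc(F)c(Cl)c3)c2cc1B(O)O`: "not active" (no number reported)
- compound 3 `COc1cc2ncnc(Nc3ccc(F)c(Cl)c3)c2cc1B1OC(C)(C)C(C)(C)O1`: "not active" (no number reported)

Among the compounds with values here, compound 1, with a carboxylic acid on its aniline ring, is the only member of the set that gives a number in this assay. Compound 2 carries a boronic acid on the shared core together with a 3-chloro-4-fluorophenyl ring; for compound 2 this assay gives no single number, only the report that it is not active, and compound 3, the cyclic ester of the same boronic acid, stands the same way. Compound 4 `COc1cc2ncnc(Nc3cccc(Cl)c3)c2cc1B(O)O` is yet to be measured in this assay. It differs from compound 2 by hydrogen in place of fluoro on an aromatic carbon. Within the data shown here, no measured pair shows how this change moves the read-out. Both boronic compounds stand without a number in this assay, so for compound 4 no step beyond the scatter is anticipated from compound 2, and a fair chance remains that it too is reported without a number. Compound 4 is estimated at 5% in this assay, with a range from 0% to 20%.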

Compound 4, a percentage reported as inhibition, at one concentration (the size of the read-out at that concentration, not a potency): "not active" (no number reported)
For compound 4 the study gives words and no number; the estimate stays without a comparison.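

In this assay compound 2 gives "not active" (no number reported) and compound 4 gives "not active" (no number reported), so no step can be read between these two compounds. No supporting evidence bears on this result. The compounds shown leave open how hydrogen in place of fluoro moves the read-out when both partners give a number.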